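A chlorine shift with no measured starting point

This account rests on a few compounds, and the source may have more. Where it says the series, first, only, none or still open, it means among the compounds named here.

Four compounds share one core and differ only in the groups attached to it. In a functional assay on A2780 cells (Homo sapiens) for antiproliferative activity, read by resazurin assay, with a stated time of 72 h (on this read-out higher numbers stand for weaker inhibition and lower numbers for stronger inhibition), compound 1 `CN(Cc1ccccc1F)C(=O)c1cc2c(Cc3ccccc3)n[nH]c2cc1O` gives 1500 nM, and compound 2 `Cc1ccc(CN(C)C(=O)c2cc3c(Cc4ccccc4)n[nH]c3cc2O)cc1` gives 6900 nM. Compound 3 `CN(Cc1ccccc1)C(=O)c1cc2c(Cc3ccccc3Cl)n[nH]c2cc1O` offers no number to start from: its result reads "not determined" (no result reported).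

Compound 4 `CN(Cc1ccccc1)C(=O)c1cc2c(Cc3cccc(Cl)c3)n[nH]c2cc1O` has the same atoms as compound 3, joined differently, with 3-chlorophenyl in place of 2-chlorophenyl on a saturated chain carbon bound to an aromatic carbon.

For the measured compounds named here, only one measured step bears on this change, and only loosely: a 4.6-fold higher number from compound 1 to compound 2 (0.66 log units; beyond the scatter). That swap of one substituted phenyl for another was modest but beyond the scatter. It also sits at a different place, on a saturated chain carbon bound to an amide-type nitrogen. Going by the values given here, without a value for compound 3, no direction can be expected in this assay, and no size of step can be stated from it. A modest shift either way remains possible, so the estimate has to lean on the neighbouring compounds, compound 1 at 1500 nM and compound 2 at 6900 nM. The expected value for compound 4 is 3200 nM, with an estimated range of 900 nM to 11000 nM.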

Compound 4, half-maximal inhibitory concentration: 410 nM
Compound 4: middle estimate off by 7.8-fold (0.89 log units), on the high side; the measured number lies below the stated range.
By their numbers in this assay, from the lowest: compound 4; then compound 1; then compound 2.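

In this assay compound 4 gives 410 nM but compound 3 carries no number, so no step can be read between compound 3 and compound 4. The compounds shown leave open how 2-chlorobenzyl and 3-chlorobenzyl compare on the shared core. Nothing further is available here to explain the value of compound 4.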